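Reversing the Amide on a Fused Bicyclic Core

The source may report more compounds than this note shows. Statements on the series, on what has been measured and on what is new or still open speak of the compounds shown alone.

Compound 1 `Cc1nn(-c2ncnc3nc[nH]c23)c2c1C(C(=O)NCc1ccc(F)cc1)CC(=O)N2`: 1220 nM in a functional assay on HEK293 cells for agonist activity at G-protein coupled receptor 39 (Homo sapiens), read by scintillation proximity assay and inositol phosphate accumulation, with a stated time of 75 min; a higher number here means that more compound is needed for the effect, a lower number that less compound is needed
Compound 2 `Cc1nn(-c2ncnc3nc[nH]c23)c2c1C(C(=O)NCc1ccccc1)CC(=O)N2`: 2930 nM in this assay

Among the compounds with values here, compound 2 stands at the higher of the two numbers measured so far; its nearest neighbour is compound 1, and the step of a 2.4-fold higher number from compound 1 to compound 2 (0.38 log units; beyond the scatter) comes from hydrogen in place of fluoro on an aromatic carbon. Compound 3 `Cc1nn(-c2ncnc3nc[nH]c23)c2c1C(NC(=O)c1ccccc1)CC(=O)N2` differs from compound 2 in another way: benzamido in place of benzylcarbamoyl on a saturated ring carbon. Within the data shown here, no measured step involves this kind of change; the only step known concerns the aromatic substituent, not the linkage between the saturated ring carbon and the phenyl group, so it does not speak to compound 3. With nothing to lean on, the expectation for compound 3 is a number near that of compound 2, with a wide band around it. The estimated step is a 1.0-fold higher number from compound 2 to compound 3 (0.01 log units; within the scatter), which is expected to lie within the scatter. Compound 3 is therefore estimated at 3000 nM, between 800 nM and 12000 nM.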

Compound 3, half-maximal effective concentration: 158 nM
Beside the measured number, compound 3's estimate is 19-fold (1.28 log units) above it; measured number below the stated range.
By their numbers in this assay, from the lowest: compound 3; then compound 1; then compound 2.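

In this assay, the way the phenyl group is linked to the saturated ring carbon proves decisive: benzamido in place of benzylcarbamoyl gives a 19-fold lower number from compound 2 to compound 3 (1.27 log units; beyond the scatter). That step is large, whereas the aromatic substituent change gave only a 2.4-fold higher number from compound 1 to compound 2 (0.38 log units; beyond the scatter), so this position responds strongly to a change that leaves the printed counts of hydrogen-bond donors and acceptors the same. Nothing available explains why the linkage matters so much.

The compounds shown leave open whether a fluoro on the phenyl ring of the benzamido group would lower the number as it does on the benzylcarbamoyl group. They also leave open how a sulfonamide or a longer chain on this saturated ring carbon would compare with benzamido.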